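The compounds below may be only part of what the source reports. "The series", "measured", "known", "first", "only" and "open" are said of these compounds alone.

Three compounds share a core in which a cinnamoyl-type linker carries a carbonyl and a different ring on the carbonyl carbon. Compound 1 `O=C(/C=C/c1ccc2c(c1)B(O)OC2)c1cccs1` gives 14200 nM in a functional assay on HCT-116 cells (Homo sapiens) for cytotoxicity, read by MTT assay, with a stated time of 48 h; a higher number here means a weaker inhibitor, a lower number a stronger inhibitor. Compound 2 `Cn1cccc1C(=O)/C=C/c1ccc2c(c1)B(O)OC2` reaches only a limit of this assay, > 100000 nM, so its number is not known. Compound 3 `O=C(/C=C/c1ccc2c(c1)B(O)OC2)c1ccc(Br)cc1` gives 9900 nM in this assay. Within the data shown here, the step of an at least 7.0-fold higher number from compound 1 to compound 2 (0.84 log units; beyond the scatter) is beyond the scatter, as is an at least 10-fold lower number from compound 2 to compound 3 (1.00 log units; beyond the scatter), whereas a 1.4-fold lower number from compound 1 to compound 3 (0.16 log units; within the scatter) is within it; compound 3 has the lowest of the two known numbers, but its gap to compound 1 is not one the assay can separate, so no order between them can be claimed.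

Compound 4 `O=C(/C=C/c1ccc2c(c1)B(O)OC2)c1ccc(C(F)(F)F)cc1` differs from compound 3 by trifluoromethyl in place of bromo on an aromatic carbon. Among the measured compounds shown here, none of the measured steps tests such a swap on a single aromatic carbon: each of them exchanges the whole ring on the carbonyl carbon. With no direct parallel, the expectation for this change in this assay is a step no larger than the scatter, a 1.0-fold higher number from compound 3 to compound 4 (0.00 log units; within the scatter). Compound 4 is therefore estimated at 10000 nM, within a range from 3500 nM to 30000 nM.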

Compound 4, half-maximal inhibitory concentration: 6300 nM
Beside the measured number, compound 4's estimate is 1.6-fold (0.20 log units) above it; measured number inside the range.
By their numbers in this assay, from the lowest: compounds 4, 3 and 1 (each within the scatter of the next, the first and the last beyond it). At a limit, above all of these: compound 2.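

This is the first change shown that leaves the ring on the carbonyl carbon in place and alters only the group on an aromatic carbon, para to a large group. In this assay, trifluoromethyl with 4 heavy atoms in place of bromo with 1 heavy atom gives a 1.6-fold lower number from compound 3 to compound 4 (0.20 log units; within the scatter), so the assay does not separate these two groups at this position. No measurement shown gives a cause for this step.

Going by these compounds, whether a group of another kind at this position, such as an amine or a carboxylic acid, would move the number beyond the scatter remains open. Also open, on these data alone, is how a plain phenyl ring on the carbonyl carbon, with only hydrogen at this position, would compare with compound 3 and compound 4.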